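The source may hold more compounds than are shown below. What is called first, only, known or untested is meant among the compounds shown, and "the series" means these compounds.

Measured compounds in this study:

Compound 1 `COc1ccccc1-n1cc(COC(=O)/C(C)=C/CC/C(C)=C/CC/C(C)=C/CC[C@@H]2[C@@]3(C)CCC(=O)C(C)(C)[C@H]3CC[C@@]2(C)O)nn1`: in an ADME assay on L132 cells (Homo sapiens) for cytotoxicity, read by MTT assay, with a stated time of 48 h (a higher number here means a weaker inhibitor, a lower number a stronger inhibitor), compound 1 gives only a limit of the assay, > 150000 nM.
Compound 2 `C/C(=C\CC/C(C)=C/CC[C@@H]1[C@@]2(C)CCC(=O)C(C)(C)[C@H]2CC[C@@]1(C)O)CC/C=C(\C)C(=O)OCc1cn(-c2ccc(C(F)(F)F)cc2)nn1`: in this assay compound 2 likewise gives only a limit of the assay, > 150000 nM.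

Among the compounds with values here, the single measured step, a step that the two limits leave unreadable from compound 1 to compound 2, cannot be read in size, since both of its ends sit at the limit; this is what the limit of > 150000 nM in this assay, at which 2 of the 2 values shown sit, records. Within the data shown here, compound 2 therefore stands in this assay at a limit and not at a number, and the one other value known sits at the same limit.

Compound 3 `C/C(=C\CC/C(C)=C/CC[C@@H]1[C@@]2(C)CCC(=O)C(C)(C)[C@H]2CC[C@@]1(C)O)CC/C=C(\C)C(=O)OCc1cn(-c2ccc(C)cc2)nn1` has not yet been measured. It differs from compound 2 in one place: methyl in place of trifluoromethyl on an aromatic carbon. Among the measured compounds shown here, the only measured step concerns a change on an aromatic nitrogen, not on the aromatic carbon changed here, and its size is unreadable, so it lends no direction to the present change. Nothing in the data points to a step beyond the scatter, and compound 3 is expected to remain at the limit as well.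

Compound 3 is therefore estimated at 200000 nM in this assay, within a range of 100000 nM to 500000 nM. The step that the limit leaves unreadable from compound 2 to compound 3 is expected to be one the assay cannot resolve.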

Compound 3, half-maximal inhibitory concentration: > 150000 nM
Compound 3 ended at the assay's limit (the forecaster's own chance of this, stated with the estimate: 80%); the middle value is on the limit's open side.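

In this assay compound 3 also gives only a limit of the assay, > 150000 nM. The steps linking compound 3 to compound 1 and to compound 2 cannot be read in size, and no new comparison follows: the limit of > 150000 nM in this assay, at which 3 of the 3 values shown sit.

The compounds shown leave open how far past this limit each one lies, and whether any change to the shared core would give a measurable value.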